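Chloro for isopropoxy on a shared bicyclic pyridine core

This account rests on a few compounds, and the source may have more. Where it says the series, first, only, none or still open, it means among the compounds named here.

Measured compounds:
compound 1 `FC(F)(F)c1cncc(C2=CC3CNCC(C2)C3)c1` — 0.7 nM
compound 2 `CC(C)Oc1cncc(C2=CC3CNCC(C2)C3)c1` — 0.26 nM

In an in vitro assay on SH-EP1 cells for displacement of a labelled ligand from Neuronal acetylcholine receptor; alpha4/beta2 (Homo sapiens) (a lower number here means a stronger inhibitor, a higher number a weaker inhibitor), compound 2 gives the lowest of the two numbers; its nearest neighbour is compound 1, and the step of a 2.7-fold lower number from compound 1 to compound 2 (0.43 log units; beyond the scatter) is a modest one. Compound 3 `Clc1cncc(C2=CC3CNCC(C2)C3)c1` carries the change (chloro in place of isopropoxy on an aromatic carbon). Among the compounds with values here, the only measured step, the one from compound 1 to compound 2, bears on this change just indirectly: it shows that swapping the group at this position moves the number by a modest amount, and chloro is neither of the two groups already seen. Compound 3 is therefore expected to give a number slightly higher than compound 2, a step of a 1.9-fold higher number from compound 2 to compound 3 (0.28 log units; within the scatter), estimated at 0.5 nM with a range from 0.15 nM to 1.6 nM.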

Compound 3, inhibition constant: 0.4 nM
Compound 3: middle estimate off by 1.3-fold (0.10 log units), on the high side; the measured number falls inside the stated range.
By their numbers in this assay, from the lowest: compounds 2, 3 and 1 (each within the scatter of the next, the first and the last beyond it).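

In this assay the single chlorine atom of chloro replaces the four heavy atoms of isopropoxy with a 1.5-fold higher number from compound 2 to compound 3 (0.19 log units; within the scatter) and replaces trifluoromethyl with a 1.8-fold lower number from compound 1 to compound 3 (0.24 log units; within the scatter). Compound 3 thus lies within the scatter of both compound 1 and compound 2, so this change shows no clear effect, even though chloro lacks the hydrogen-bond acceptor of isopropoxy. No evidence here bears on the reason for this result. The compounds shown leave open whether an amine, a carboxylic acid or a longer alkoxy chain at this position would stay within the same narrow span of numbers.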